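A New Amide Partner Tested Against an Inactive Parent

A few compounds are considered here, and "the series" means these few. Any claim that something is new, unique, unknown or untested is made for them only; others in the source may bear on it.

Compound 1, `COc1cccc(-c2cn(-c3ccc(C(F)(F)F)cc3)nc2C(=O)N2CCN(c3ncccn3)CC2)c1`, was examined in a functional assay on BMDM cells (Mus musculus, strain C57BL/6) for inhibition, with a stated time of 2 days; a higher number here means a weaker inhibitor, a lower number a stronger inhibitor. In this assay compound 1 gives only a limit, > 30000 nM, and no number. This is the limit of > 30000 nM in this assay, at which 1 of the 2 values shown sits. The other measured compound, compound 2, `Cc1csc(NC(=O)Cn2cc(-c3ccccc3Cl)nn2)n1`, is built quite differently, and in this assay compound 2 gives 1240 nM. Going by the values given here, no step between measured compounds that differ in one place is available, so no measured change offers guidance.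

Compound 3, `COc1cccc(-c2cn(-c3ccc(C(F)(F)F)cc3)nc2C(=O)N2CCc3ccccc3C2)c1`, differs from compound 1 in one place: 1,2,3,4-tetrahydroisoquinolin-2-yl in place of 4-(pyrimidin-2-yl)piperazin-1-yl on a carbonyl carbon. Because compound 1 gives only the limit > 30000 nM in this assay, the effect of this change can be judged solely from that limit, and a real number for compound 3 may or may not appear. The step is expected to be an at least 1.2-fold lower number from compound 1 to compound 3 (0.07 log units; that floor lies within the scatter). Compound 3 is estimated at 25000 nM in this assay, with a range from 3000 nM to 100000 nM.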

Compound 3, half-maximal inhibitory concentration: > 30000 nM
Compound 3: no number, only a limit; the forecaster's own chance of this, stated with the estimate: 60%; at least 1.2-fold (0.07 log units) between middle value and limit.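

Compound 1 and compound 3 both give only a limit in this assay, so no step between them can be read: the limit of > 30000 nM in this assay, at which 2 of the 3 values shown sit.

The compounds shown leave open whether any partner on the carbonyl carbon of this shared core gives a real number in this assay.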